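Stereo inversion from compound 3 to compound 4

The source may report more compounds than this note shows. Statements on the series, on what has been measured and on what is new or still open speak of the compounds shown alone.

Measured in a functional assay on QGY cells (Homo sapiens) for cytotoxicity, read by MTT assay, with a stated time of 48 h (a higher number here means a weaker inhibitor, a lower number a stronger inhibitor), as follows:
- compound 1 `CCOC(=O)[C@@]1(C(=O)Nc2ccccc2)C[C@@H]1c1cc(OC)c(OC)c(OC)c1` gives > 100000 nM as a limit
- compound 2 `CCOC(=O)[C@@]1(C(=O)NCc2ccc(C)cc2)C[C@H]1c1cc(OC)c(OC)c(OC)c1` gives 26400 nM as a number
- compound 3 `CCOC(=O)[C@]1(C(=O)NCc2ccc(C)cc2)C[C@H]1c1cc(OC)c(OC)c(OC)c1` gives 32100 nM as a number

Compound 3 at 32100 nM sits level with compound 2 within the scatter. Going by the values given here, compound 1 stands at a limit and yields no step. Compound 4 `CCOC(=O)[C@@]1(C(=O)NCc2ccc(C)cc2)C[C@@H]1c1cc(OC)c(OC)c(OC)c1` is the mirror image of compound 3, with the two compounds have the same atoms and bonds and differ only in configuration as drawn: 2 of 2 stereo elements differ (all stereocentres are inverted: mirror images); a stereocentre at a saturated ring carbon is drawn R in compound 3 and S in compound 4; a stereocentre at a saturated ring carbon is drawn S in compound 3 and R in compound 4 as the whole change. Among the compounds with values here, the one measured step bearing on this is a 1.2-fold higher number from compound 2 to compound 3 (0.08 log units; within the scatter) in this assay and it stays within the scatter. That step comes with the fact that compounds 2 and 3 differ only in the configuration as drawn and covers one stereo element only, whereas compound 4 inverts both. Within the data shown here, compound 3 with a 1.2-fold higher number from compound 2 to compound 3 (0.08 log units; within the scatter) as the only stereo step measured points to no change beyond the scatter, but the full inversion is unmeasured, so the range stays wide. The estimated step is a 1.1-fold lower number from compound 3 to compound 4 (0.03 log units; within the scatter) and so lies within the scatter. Compound 4 is estimated at 30000 nM with an expected range from 12000 nM to 80000 nM in this assay once measured.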

Compound 4, half-maximal inhibitory concentration: > 100000 nM
Compound 4 ended at the assay's limit; the forecaster's own chance of this, stated with the estimate: 15%; middle value at least 3.3-fold (0.52 log units) away from the limit.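

In this assay compound 4 stands at > 100000 nM as a limit of the assay, not a number. Configuration does count in this series: the record shows (an at least 3.1-fold higher number from compound 3 to compound 4 (0.49 log units; beyond the scatter)) and (an at least 3.7-fold higher number from compound 2 to compound 4 (0.57 log units; beyond the scatter)), whereas inverting the other stereocentre gave only (a 1.2-fold higher number from compound 2 to compound 3 (0.08 log units; within the scatter)), so the two ring stereocentres do not behave alike here. Going by these compounds alone, the rise at the single centre separating compounds 2 and 4 cannot be put down to any change of atoms or bonds: the fact that compounds 2 and 4 differ only in the configuration as drawn.

The step from compound 1 to compound 4 cannot be read. Going by these compounds, whether this dependence on configuration persists with a carboxylic acid in place of the ethyl ester, or with a longer chain in place of the 4-methylbenzyl group, remains open.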